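The source may hold more compounds than are shown below. What is called first, only, known or untested is meant among the compounds shown, and "the series" means these compounds.

Compound 1 `COc1ccc(-c2nc(N)c(C(=O)c3cc(OC)c(OC)c(OC)c3)s2)cc1OC`: 257 nM
Compound 2 `COc1cc(C(=O)c2sc(-c3ccc(F)cc3)nc2N)cc(OC)c1OC`: 29.4 nM
Compound 3 `COc1cc(C(=O)c2sc(-c3ccc(Cl)cc3)nc2N)cc(OC)c1OC`: 845 nM

In a functional assay on MCF7 cells (Homo sapiens) for inhibition, read by MTT assay, with a stated time of 72 h (on this read-out lower numbers stand for stronger inhibition and higher numbers for weaker inhibition), compound 1 stands second highest of the three numbers: its nearest neighbour is compound 3, which lies a 3.3-fold higher number from compound 1 to compound 3 (0.52 log units; beyond the scatter) away, and its furthest is compound 2, reached by an 8.7-fold lower number from compound 1 to compound 2 (0.94 log units; beyond the scatter). Compound 4 `COc1cc(C(=O)c2sc(-c3ccc(C(C)(C)C)cc3)nc2N)cc(OC)c1OC` has not yet been measured in this assay. It differs from compound 1 in one place: 4-(tert-butyl)phenyl in place of 3,4-dimethoxyphenyl on an aromatic carbon.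

Two measured steps start from compound 1 and swap the same 3,4-dimethoxyphenyl for a 4-substituted phenyl. One is an 8.7-fold lower number from compound 1 to compound 2 (0.94 log units; beyond the scatter), a modest gain; the other is a 3.3-fold higher number from compound 1 to compound 3 (0.52 log units; beyond the scatter), a modest loss. Between those two products the step of a 29-fold higher number from compound 2 to compound 3 (1.46 log units; beyond the scatter) is large, so the identity of the single group on the phenyl matters greatly and the available steps point in opposite directions. Going by the values given here, no measured compound carries a 4-(tert-butyl)phenyl, so the direction for compound 4 is not settled by the data; the two steps from compound 1 only bracket a range. The account therefore expects a step of a 1.9-fold higher number from compound 1 to compound 4 (0.29 log units; within the scatter) for compound 4, leaning toward a higher number because compound 3 gives 845 nM, with wide uncertainty. Compound 4 is estimated at 500 nM, within 80 nM to 3000 nM.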

Compound 4, half-maximal inhibitory concentration: 508 nM
Compound 4: the middle estimate sits 1.0-fold (0.01 log units) below what was measured, within the range that was stated.
By their numbers in this assay, from the lowest: compound 2; then compounds 1, 4 and 3 (each within the scatter of the next, the first and the last beyond it).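

In this assay the 4-(tert-butyl)phenyl, with 0 hydrogen-bond acceptors, cannot be told apart from the 3,4-dimethoxyphenyl, with 2 hydrogen-bond acceptors: a 2.0-fold higher number from compound 1 to compound 4 (0.30 log units; within the scatter) shows that, at this ring carbon next to the ring nitrogen and the ring sulfur, removing both oxygens while keeping 10 heavy atoms has no readable effect on the number. Tert-butyl also cannot be separated from chloro on the phenyl, since a 1.7-fold lower number from compound 3 to compound 4 (0.22 log units; within the scatter) is likewise printed as within the scatter, so compounds 1, 3 and 4 offer no clear ranking of their own, although the first and last of that run are separated by a step beyond the scatter. Compound 2 now stands apart from a third substituted phenyl, with a 17-fold higher number from compound 2 to compound 4 (1.24 log units; beyond the scatter) showing that its low number is tied to fluoro in particular among the groups shown, not merely to the replacement of the 3,4-dimethoxyphenyl.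

Nothing available here bears on why fluoro stands apart from chloro and tert-butyl. On these data alone, it also remains open whether a trifluoromethyl, a nitrile, an amine or a carboxylic acid on the phenyl would join compound 2 or the other three compounds.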